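Three inactive succinimide amides and a methyl analogue

The compounds below may be only part of what the source reports. "The series", "measured", "known", "first", "only" and "open" are said of these compounds alone.

Measured so far:
compound 1, `CCC(C(=O)N1CCN(c2cccc(F)c2)CC1)N1C(=O)CCC1=O`, 0%
compound 2, `CCC(C(=O)N1CCN(c2ccccc2F)CC1)N1C(=O)CCC1=O`, 0%
compound 3, `CCC(C(=O)N1CCN(c2cccc(C(F)(F)F)c2)CC1)N1C(=O)CCC1=O`, 0%

In a functional assay on the whole organism (strain Swiss) with Mus musculus as the target, in the maximal electroshock model, with a stated time of 2 h, at a dose of 100 mg/kg by the intraperitoneal route (a higher number here means a stronger effect of the compound at the dose given, a lower number a weaker effect), compound 1 gives 0%. Compound 2, which carries 2-fluorophenyl in place of 3-fluorophenyl on an amine nitrogen in a ring, gives 0%, and the step of no change at the digits printed from compound 1 to compound 2 (within the scatter). Compound 3, with trifluoromethyl in place of fluoro on an aromatic carbon, gives 0%; the step of no change at the digits printed from compound 1 to compound 3 (within the scatter). Within the data shown here, compound 3 therefore stands level with compounds 1 and 2 at the digits recorded, with no member of the trio showing any effect in this assay at the dose given.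

The unmeasured compound 4, `CCC(C(=O)N1CCN(c2cccc(C)c2)CC1)N1C(=O)CCC1=O`, differs from compound 3 as follows: methyl in place of trifluoromethyl on an aromatic carbon. Both recorded steps, a change of the halogen position and a change from fluoro to trifluoromethyl, left the read-out unchanged within the scatter, and nothing among the three measured compounds suggests that a further change at the same aromatic carbon would act differently. The step of no change at the digits printed from compound 3 to compound 4 (within the scatter) is accordingly expected to lie within the scatter. Compound 4 is estimated to give 0%, with a range from 0% to 15%.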

Compound 4, a percentage reported as activity, at one dose (the size of the read-out at that dose, not a potency): 0%
Estimate against measurement, compound 4: no gap at the digits printed, and the stated range covers the measured number.
By their numbers in this assay, from the lowest: compounds 1, 2, 3 and 4 (each within the scatter of the next).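

In this assay, replacing trifluoromethyl, with its 4 heavy atoms, by methyl, with 1, on an aromatic carbon meta to a large group gives no change at the digits printed from compound 3 to compound 4 (within the scatter) and so extends the flat result at this position to a substituent without fluorine. The comparison with the fluoro compound agrees, with no change at the digits printed from compound 1 to compound 4 (within the scatter) on the same carbon, and the exchange of 2-fluorophenyl for 3-methylphenyl gives no change at the digits printed from compound 2 to compound 4 (within the scatter) as well. Nothing measured here accounts for the shared read-out of these four compounds.

As far as these compounds go, whether an amine, a carboxylic acid or a methoxy group at this aromatic carbon would give a different read-out remains open. So does whether a longer chain elsewhere on the shared core would move it at all.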